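Aminomethyl replaces cyano on the shared pyrimidinedione core

This account rests on a few compounds, and the source may have more. Where it says the series, first, only, none or still open, it means among the compounds named here.

Of the compounds shown here, two with the same sugar-bearing core have been measured. Compound 1 `Nc1cn([C@H]2C[C@H](O)[C@@H](CO)O2)c(=O)[nH]c1=O` carries an amino group on the aromatic carbon, and in an assay on BHK21 (C13) cells (Mesocricetus auratus) for inhibition of thymidine kinase, cytosolic (Cricetulus griseus), using Lineweaver-Burk analysis (a lower number here means a stronger inhibitor, a higher number a weaker inhibitor), compound 1 gives 450000 nM. Compound 2 `N#Cc1cn([C@H]2C[C@H](O)[C@@H](CO)O2)c(=O)[nH]c1=O` carries a cyano group in that place, and in this assay compound 2 gives 220000 nM. Among the measured compounds shown here, the only step between them is a 2.0-fold lower number from compound 1 to compound 2 (0.31 log units; beyond the scatter). On the numbers shown, compound 2 stands lowest of the two, with compound 1 as its sole neighbour.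

Compound 3 `NCc1cn([C@H]2C[C@H](O)[C@@H](CO)O2)c(=O)[nH]c1=O` differs from compound 2 in one place: aminomethyl in place of cyano on an aromatic carbon. For the measured compounds named here, the one measured step that bears on this change is a 2.0-fold lower number from compound 1 to compound 2 (0.31 log units; beyond the scatter), which went from an amino group to a cyano group in the same position and lowered the number modestly. The change to compound 3 moves in the opposite sense, from the cyano group to a group that again carries a nitrogen with a hydrogen-bond donor, so a modest rise in the number in this assay is expected, roughly undoing that step rather than exceeding it. The estimate for compound 3 in this assay is therefore 400000 nM, within 150000 nM to 1000000 nM, which corresponds to an expected step of a 1.8-fold higher number from compound 2 to compound 3 (0.26 log units; within the scatter).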

Compound 3, inhibition constant: 1700000 nM
The estimate for compound 3 lay 4.3-fold (0.63 log units) below the measured number, outside the stated range (above it).
By their numbers in this assay, from the lowest: compound 2; then compound 1; then compound 3.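

In this assay, among the compounds shown here, the change at this position reaches further than the earlier compounds showed: aminomethyl in place of cyano gives a 7.7-fold higher number from compound 2 to compound 3 (0.89 log units; beyond the scatter), a larger step than the one seen so far at this aromatic carbon. Aminomethyl also does not behave as a return to the amino group, since swapping amino for it gives a 3.8-fold higher number from compound 1 to compound 3 (0.58 log units; beyond the scatter), which leaves compound 3 the weakest of the three, with its steps to both others beyond the scatter. Two groups that each carry a nitrogen at this place therefore differ clearly in this assay, and no available evidence explains this result.

The three compounds leave open whether the higher number of compound 3 follows from the amine itself or from the added carbon that carries it, a question that a hydroxymethyl or a methyl group at this aromatic carbon would help to separate. They also leave open how the number would move with a longer chain such as aminoethyl, or with a carboxylic acid in the same place.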